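Adding a Methoxy Group to the Phenyl Arm

A few compounds are considered here, and "the series" means these few. Any claim that something is new, unique, unknown or untested is made for them only; others in the source may bear on it.

Within the data shown here, compound 2 `c1ccc(-c2cn3ccnc3c(-c3ccc4ncn(C5CCCCC5)c4c3)n2)cc1` is one of two compounds so far measured in a functional assay on SF-268 cells (Homo sapiens) for inhibition, read by sulforhodamine B assay, with a stated time of 48 h, tested at 10 uM (a lower number here means less inhibition, a higher number more inhibition at the concentration tested (going by the name of the read-out)), where compound 2 gives 21.7%. The other, compound 1 `Brc1cn2ccnc2c(-c2ccc3ncn(C4CCCCC4)c3c2)n1`, in this assay gives 17.1%; the step of a number 4.6 percentage points higher from compound 1 to compound 2 (within the scatter) is within the scatter, so the two numbers cannot be told apart and neither number can be called the higher one.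

Compound 3 `COc1ccc(-c2cn3ccnc3c(-c3ccc4ncn(C5CCCCC5)c4c3)n2)cc1` differs from compound 2 by methoxy in place of hydrogen on an aromatic carbon. Among the measured compounds shown here, the one measured step concerns a different change at the same end of the molecule, and it stayed within the scatter; no step of the present kind has been measured. Nothing in these numbers therefore points to a shift beyond the scatter in this assay, in either direction.

On that basis compound 3 is expected to give about 22%, in a range from 8% to 40%, meaning an expected step of a number 0.3 percentage points higher from compound 2 to compound 3 (within the scatter).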

Compound 3, a percentage reported as inhibition, at one concentration (the size of the read-out at that concentration, not a potency): 49.9%
Estimate against measurement, compound 3: 27.9 percentage points below, outside the stated range (above it).
By their numbers in this assay, from the lowest: compounds 1 and 2 (each within the scatter of the next); then compound 3.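

Placing methoxy on the phenyl ring, para to a large group, gives a number 28.2 percentage points higher from compound 2 to compound 3 (beyond the scatter) in this assay, so this end of the molecule can respond to a single added group, something the swap of bromo for plain phenyl did not show. Set against the bromo compound, the whole 4-methoxyphenyl group gives a number 32.8 percentage points higher from compound 1 to compound 3 (beyond the scatter), which means that among these compounds the rise appears only once the methoxy is present, not with the phenyl ring alone. Nothing shown here bears on why this group raises the number.

The compounds shown leave open whether a hydroxyl, an ethoxy or an amine in the same place would do the same, and whether methoxy elsewhere on the ring would match it. Going by these compounds, each reading also comes from one concentration, so how potent compound 3 is remains open.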